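The compounds below may be only part of what the source reports. "The series", "measured", "known", "first", "only" and "open" are said of these compounds alone.

Measured so far in an assay for inhibition of solute carrier family 22 member 12 (Homo sapiens), read by scintillation counting, with a stated time of 60 min, tested at 50 uM; on this read-out higher numbers stand for more inhibition at the one concentration tested (going by the name of the read-out) and lower numbers for less inhibition:
compound 1 `CCc1cc2cc(OC)cc(C(=O)c3ccc(OC)cc3)c2o1` gives 5.2%;
compound 2 `CCc1cc2cc(O)cc(C(=O)c3ccc(OC)cc3)c2o1` gives 9.3%;
compound 3 `CCc1cc2c(C(=O)c3cc(Br)c(O)c(Br)c3)c(OC)ccc2o1` gives 99.6%.

Compound 2 arises from compound 1 by one change, (hydrogen in place of methyl on an oxygen on an aromatic ring), and this moved the read-out by a number 4.1 percentage points higher from compound 1 to compound 2 (within the scatter). Compound 3 rests on a different core, and the difference between the two cores is not broken down here. Compound 4 `CCc1cc2c(C(=O)c3cc(Br)c(O)c(Br)c3)c(O)ccc2o1` carries the same change, (hydrogen in place of methyl on an oxygen on an aromatic ring), made on compound 3, at a place described in the same words as for compound 1 and compound 2. Since that step was within the scatter between compound 1 and compound 2, and compound 3 already sits near the top of the scale, the step from compound 3 to compound 4 is expected to be small, estimated at a number 2.6 percentage points lower from compound 3 to compound 4 (within the scatter). Compound 4 is therefore expected to give about 97% in this assay, estimated between 85% and 100%.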

Compound 4, a percentage reported as inhibition, at one concentration (the size of the read-out at that concentration, not a potency): 99.9%
Beside the measured number, compound 4's estimate is 2.9 percentage points below it; the measured number falls inside the stated range.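

Replacing methoxy by hydroxy gives a number 0.3 percentage points higher from compound 3 to compound 4 (within the scatter) in this assay, so on this core, as on the core of compound 1, the swap has no effect that can be told from scatter. This does not show that the change is without effect in general: compound 1 sits near the bottom of the scale at 5.2% and compound 3 near the top at 99.6%, and a reading at one concentration is not a potency, so a real difference between compound 3 and compound 4 could stay hidden. Set side by side, the steps on the two cores do not differ: the same change on two cores in this assay, a number 4.1 percentage points higher (within the scatter) from compound 1 to compound 2 and a number 0.3 percentage points higher (within the scatter) from compound 3 to compound 4, 3.8 percentage points apart, within the scatter of two such steps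

Still open, going by these compounds, is how a longer chain on that oxygen, or an amine or a carboxylic acid in its place, would read. Also open, on these data alone, is which difference between the two cores goes with the high number of compound 3.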